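This account rests on a few compounds, and the source may have more. Where it says the series, first, only, none or still open, it means among the compounds named here.

Of the compounds shown here, three sharing one core have been measured in a functional assay on VCaP cells (Homo sapiens) for antiproliferative activity, read by CCK-8 assay, with a stated time of 6 days; a higher number here means a weaker inhibitor, a lower number a stronger inhibitor. Compound 1 `C[C@@H](Cn1ccc(-c2ccc(C#N)c(Cl)c2)n1)NC(=O)c1cccc(OCC(O)CO)c1`, with a carbonyl on its amine nitrogen, gives 590 nM, and compound 2 `COC(=O)/C=C/C(=O)N[C@@H](C)Cn1ccc(-c2ccc(C#N)c(Cl)c2)n1`, also with a carbonyl there, gives 5230 nM. Compound 3 `C[C@@H](Cn1ccc(-c2ccc(C#N)c(Cl)c2)n1)Nc1ccccc1`, with phenyl on that nitrogen, stands at the limit of > 30000 nM in this assay, at which 1 of the 3 values shown sits, so its > 30000 nM is a limit and not a number.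

Compound 4 `Cc1ccnc(N[C@@H](C)Cn2ccc(-c3ccc(C#N)c(Cl)c3)n2)n1` differs from compound 3 in one place: 4-methylpyrimidin-2-yl in place of phenyl on an amine nitrogen. Here 4-methylpyrimidin-2-yl takes the place of phenyl on the amine nitrogen. For the measured compounds named here, the only measured step at this nitrogen is an at least 5.7-fold higher number from compound 2 to compound 3 (0.75 log units; beyond the scatter), beyond the scatter, with phenyl replacing (2-(methoxycarbonyl)ethenyl)carbonyl. Going by the values given here, that step is open-ended, and no measured step swaps one aromatic ring for another, so it offers only weak guidance. In this assay the expected change is small and towards a lower number, and a second limit would be no surprise. The estimated change is an at least 2.0-fold lower number from compound 3 to compound 4 (0.30 log units; that floor lies within the scatter). For compound 4 the estimate is 15000 nM, with an expected range from 4000 nM to 30000 nM.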

Compound 4, half-maximal inhibitory concentration: 850 nM
For compound 4 the middle estimate is 18-fold (1.25 log units) above the measured one, outside the stated range (below it).
By their numbers in this assay, from the lowest: compounds 1 and 4 (each within the scatter of the next); then compound 2. At a limit, above all of these: compound 3.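

In this assay, the ring on this amine nitrogen decides a great deal: 4-methylpyrimidin-2-yl in place of phenyl gives an at least 35-fold lower number from compound 3 to compound 4 (1.54 log units; beyond the scatter). The earlier step away from a carbonyl on this nitrogen pointed to a loss, but a carbonyl there is clearly not required, since swapping it for 4-methylpyrimidin-2-yl gives a 6.2-fold lower number from compound 2 to compound 4 (0.79 log units; beyond the scatter). The size of the first step is open-ended, as the value of compound 3 is a limit and not a number: the limit of > 30000 nM in this assay, at which 1 of the 4 values shown sits.

The new ring differs from phenyl in two ways at once, with its ring nitrogens and its methyl, so the compounds shown cannot tell which of these carries the gain. A plain pyrimidin-2-yl or a pyridin-2-yl on this nitrogen would help to separate the two.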